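The source may hold more compounds than are shown below. What is called first, only, known or untested is meant among the compounds shown, and "the series" means these compounds.

Of the compounds shown here, three have been tested in an ADME assay on microsomes from liver (Homo sapiens) for metabolic stability, read by LC-MS, using NADPH, tested at 10 uM; a higher number here means that the compound lasts longer, a lower number that the compound disappears faster. Compound 1 `O=C(NCc1ccccc1)c1ccc(N2CCN(S(=O)(=O)c3ccccc3Cl)CC2)nn1` gives 0.0833 h. Compound 2 `O=C(NCc1ccccc1)c1ccc(N2CCC(S(=O)(=O)c3cccc(Cl)c3Cl)CC2)nn1` gives 0.45 h. Compound 3 `Cc1ccccc1S(=O)(=O)N1CCN(c2ccc(C(=O)NCc3cncs3)nn2)CC1` gives 0.5 h. On these numbers compound 3 holds the largest value of the three, but its gap to compound 2 lies within the usual scatter of repeated measurements, so the two cannot be told apart; its gap to compound 1 lies beyond that scatter. No pair of these compounds differs in only one place, so no single structural change can be tied to a measured step.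

Compound 4 `Cc1ccccc1S(=O)(=O)N1CCN(c2ccc(C(=O)NCc3cccs3)nn2)CC1` has not yet been measured. It differs from compound 3 in one place: thiophen-2-yl in place of 1,3-thiazol-5-yl on a saturated chain carbon bound to an amide-type nitrogen. For the measured compounds named here, there is no measured step of this kind to lean on, so the size of the step can only be guessed. The change is expected to be small, a modest step from compound 3 to compound 4, most likely no larger than the scatter, with a slight lean toward a lower number: a 1.3-fold lower number from compound 3 to compound 4 (0.10 log units; within the scatter). Compound 4 is therefore expected to give about 0.4 h, with a range from 0.15 h to 1 h.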

Compound 4, half-life: 0.0667 h
Beside the measured number, compound 4's estimate is 6.0-fold (0.78 log units) above it, and the stated range ends above it.
By their numbers in this assay, from the lowest: compounds 4 and 1 (each within the scatter of the next); then compounds 2 and 3 (each within the scatter of the next).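

In this assay, the group on a saturated chain carbon bound to an amide-type nitrogen proves able to move the half-life by far more than the scatter: thiophen-2-yl in place of 1,3-thiazol-5-yl gives a 7.5-fold lower number from compound 3 to compound 4 (0.87 log units; beyond the scatter). For the compounds shown here, this is the first step here that can be tied to one structural change, and it shows that swapping one five-membered aromatic ring for another at this place is not a neutral exchange, even though both groups have the same number of heavy atoms. Nothing available explains why the number falls so far.

Going by these compounds, it remains open whether other rings at this place, such as pyridin-3-yl or 1,3-oxazol-5-yl, would give numbers closer to that of compound 3. On these data alone, it is equally open whether the same swap would give a step of similar size on a different core.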